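The source may hold more compounds than are shown below. What is called first, only, known or untested is meant among the compounds shown, and "the series" means these compounds.

Measured so far in an ADME assay on HEK293 cells (Homo sapiens) for cytotoxicity, with a stated time of 6 h; a lower number here means that less compound is tolerated, a higher number that more compound is tolerated:
- compound 1 `CCNc1nc(N)nc2ccccc12`: > 25000 nM
- compound 2 `CCCNc1nc(N)nc2ccccc12`: > 25000 nM

Compound 1 gives > 25000 nM, which is a limit and not a number. Compound 2 gives > 25000 nM, which is likewise a limit. The series therefore stands entirely at the limit of > 25000 nM in this assay, at which 2 of the 2 values shown sit, and compound 2 has no readable position within it.

Compound 3 `COCCCNc1nc(N)nc2ccccc12` turns the propyl chain of compound 2 into 3-methoxypropyl: methoxy in place of hydrogen on a saturated chain carbon, three bonds along the chain from a nitrogen on an aromatic ring. The change is methoxy in place of hydrogen on a saturated chain carbon, three bonds along the chain from a nitrogen on an aromatic ring.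

For the measured compounds named here, the only measured step that bears on this is a step that the two limits leave unreadable from compound 1 to compound 2. It offers no size to carry over, and it concerns methyl rather than methoxy. No step beyond the scatter is therefore expected in this assay, and no direction can be assigned. Compound 3 is expected to return another limit rather than a number. For compound 3 the estimated half-maximal cytotoxic concentration is 30000 nM, with an expected range of 12000 nM to 60000 nM. This estimate corresponds to an expected step that the limit leaves unreadable from compound 2 to compound 3.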

Compound 3, half-maximal cytotoxic concentration: > 25000 nM
Compound 3 was reported as a limit; the forecaster's own chance of this, stated with the estimate: 80%; the middle value is on the limit's open side.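

In this assay compound 3 gives > 25000 nM, which is a limit and not a number. The steps from compound 1 and compound 2 to compound 3 cannot be read, because the series rests entirely on limits: the limit of > 25000 nM in this assay, at which 3 of the 3 values shown sit.

The compounds shown leave open at what concentration compound 1, compound 2 or compound 3 becomes cytotoxic, and whether propyl to 3-methoxypropyl changes that concentration.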